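The source may hold more compounds than are shown below. What is called first, only, known or untested is meant among the compounds shown, and "the series" means these compounds.

Series notes. Three members of the shared core, varied only at the far end of the chain, are measured in an ADME assay (Homo sapiens) for cytotoxicity; on this read-out lower numbers stand for higher toxicity in this test and higher numbers for lower toxicity in this test. Compound 1 `CC(=O)N1CCC(C(=O)N(CCCN2CCC(CNC(=O)c3cnccn3)CC2)c2ccc(C)c(Cl)c2)CC1` gives only a limit, > 52400 nM. Compound 2 `CC(=O)N1CCC(C(=O)N(CCCN2CCN(Cc3cccnc3)CC2)c2ccc(C)c(Cl)c2)CC1` likewise gives a limit, > 56700 nM. Compound 3 `CC(=O)N1CCC(C(=O)N(CCCN2CCN(Cc3cnc(Cl)s3)CC2)c2ccc(C)c(Cl)c2)CC1` also gives a limit, > 52300 nM. Hence a step that the two limits leave unreadable from compound 2 to compound 3 cannot be read, and the three results (the limit of > 52300 nM in this assay, at which 1 of the 3 values shown sits), (the limit of > 52400 nM in this assay, at which 1 of the 3 values shown sits), the limit of > 56700 nM in this assay, at which 1 of the 3 values shown sits, all sit at limits. Compound 4 `CC(=O)N1CCC(C(=O)N(CCCN2CCN(Cc3ccc(Cl)cc3)CC2)c2ccc(C)c(Cl)c2)CC1` differs from compound 3 by 4-chlorophenyl in place of 2-chloro-1,3-thiazol-5-yl on a saturated chain carbon bound to an amine nitrogen in a ring. Among the measured compounds shown here, no measured step bears readably on this change, so no step beyond the scatter is expected in this assay. The expected step that the limit leaves unreadable from compound 3 to compound 4 is accordingly small. Compound 4 is expected at 60000 nM, range 25000 nM to 150000 nM, most likely again reported as a limit.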

Compound 4, half-maximal cytotoxic concentration: 37600 nM
Estimate against measurement, compound 4: 1.6-fold (0.20 log units) above, within the range that was stated.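

In this assay compound 4 gives 37600 nM, the first result at this position that is a number and not a limit. Replacing the 2-chloro-1,3-thiazol-5-yl group gives an at least 1.3-fold lower number from compound 3 to compound 4 (0.14 log units; that floor lies within the scatter), and replacing the pyridin-3-yl group gives an at least 1.5-fold lower number from compound 2 to compound 4 (0.17 log units; that floor lies within the scatter). Neither floor establishes a real difference between these groups.

As far as these compounds go, the true size of both steps stays open, as compounds 2 and 3 are known only as limits. Also open, from the compounds shown here alone, is the read-out with a carboxylic acid or an aliphatic amine in place of 4-chlorophenyl.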